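A few compounds are considered here, and "the series" means these few. Any claim that something is new, unique, unknown or untested is made for them only; others in the source may bear on it.

In a functional assay on LNCaP cells (Homo sapiens) for antiproliferative activity (a lower number here means a stronger inhibitor, a higher number a weaker inhibitor), compound 1 (`Cn1ncc(Cl)c1-c1cc(C(=O)N[C@@H]2CN[C@H](CC(O)CO)C[C@H]2c2ccc(Cl)c(Cl)c2)oc1Cl`) gives 70 nM and compound 2 (`C=CC[C@@H]1C[C@@H](c2ccc(Cl)c(Cl)c2)[C@H](NC(=O)c2cc(-c3c(Cl)cnn3C)c(Cl)o2)CN1`) gives 160 nM, while compound 3 (`Cn1ncc(Cl)c1-c1cc(C(=O)N[C@@H]2CN[C@H](CC(=O)NCC(O)CO)C[C@H]2c2ccc(Cl)c(Cl)c2)oc1Cl`) stands highest of the three at 660 nM on this scale. Compound 4 (`Cn1ncc(Cl)c1-c1cc(C(=O)N[C@@H]2CN[C@H](CC(=O)NC3CC3)C[C@H]2c2ccc(Cl)c(Cl)c2)oc1Cl`) differs from compound 3 in one place (cyclopropyl in place of 2,3-dihydroxypropyl on an amide-type nitrogen): cyclopropyl in place of 2,3-dihydroxypropyl on an amide-type nitrogen. With a 9.4-fold higher number from compound 1 to compound 3 (0.97 log units; beyond the scatter) and a 4.1-fold higher number from compound 2 to compound 3 (0.62 log units; beyond the scatter) as the nearest measured steps on this side chain, both modest and neither this exact swap, a modest step toward a lower number is expected in this assay for compound 4. The expected step is a 2.6-fold lower number from compound 3 to compound 4 (0.42 log units; beyond the scatter) and these data support no larger one. For compound 4 the estimate is 250 nM with 80 nM to 800 nM as its expected range.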

Compound 4, half-maximal inhibitory concentration: 190 nM
Beside the measured number, compound 4's estimate is 1.3-fold (0.12 log units) above it; measured number inside the range.
By their numbers in this assay, from the lowest: compound 1; then compounds 2 and 4 (each within the scatter of the next); then compound 3.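

Within the amide side chain, the group on the nitrogen matters: cyclopropyl in place of 2,3-dihydroxypropyl gives a 3.5-fold lower number from compound 3 to compound 4 (0.54 log units; beyond the scatter) in this assay, so the carbamoyl link alone does not fix the number. The cyclopropylcarbamoyl and vinyl chains cannot be told apart, with a 1.2-fold higher number from compound 2 to compound 4 (0.07 log units; within the scatter) and a difference within the scatter. The 1,2-dihydroxyethyl chain still keeps its edge, with a 2.7-fold higher number from compound 1 to compound 4 (0.43 log units; beyond the scatter) on the same scale.

Nothing available here explains these steps. As far as these compounds go, whether an amine, a carboxylic acid or a longer chain on the amide-type nitrogen would shift the number remains open.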